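The compounds below may be only part of what the source reports. "The series", "measured", "known", "first", "only" and "open" are said of these compounds alone.

Measured so far:
compound 1 `Cc1ccc(-c2ccc(CO[C@H]3C[C@@H](N=C=S)C3)cc2)cc1` — 26 nM
compound 2 `COc1cnc(-c2ccc(CO[C@H]3C[C@@H](N=C=S)C3)cn2)cc1F` — 15 nM
compound 3 `COc1ccc(-c2ccc(CO[C@H]3CC[C@@H](N=C=S)C3)nc2)cc1F` — 1450 nM

In an assay on isolated protein for inhibition of N-acylethanolamine-hydrolyzing acid amidase (Homo sapiens), read by fluorescence, with a stated time of 90 min (a lower number here means a stronger inhibitor, a higher number a weaker inhibitor), compound 3 stands highest of the three numbers: its value lies well beyond the scatter from both compound 1 and compound 2, so it is the weakest inhibitor shown. Compound 3 is also the only one of the three in which the oxygen on the saturated carbon carries a five-membered non-aromatic ring of carbon only; compound 1 and compound 2 both carry the four-membered ring at that position.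

Compound 4 `COc1ccc(-c2ccc(CO[C@H]3C[C@@H](N=C=S)C3)nc2)cc1F`, not yet measured in this assay, differs from compound 3 in one place: a group of 7 heavy atoms (5 carbon, 1 nitrogen, 1 sulfur; one four-membered non-aromatic ring of carbon only) in place of a group of 8 heavy atoms (6 carbon, 1 nitrogen, 1 sulfur; one five-membered non-aromatic ring of carbon only), on an oxygen on a saturated carbon. With this change, compound 4 carries the same four-membered ring as compound 1 and compound 2. Among the compounds with values here, no measured pair shows this exact step, so its size can only be inferred from where compound 3 stands relative to the other two.

The expectation is a large step downward, beyond the scatter, bringing compound 4 into the range of compound 1 and compound 2; the step from compound 3 to compound 4 is estimated at a 36-fold lower number from compound 3 to compound 4 (1.56 log units; beyond the scatter). Compound 4 is therefore expected to give about 40 nM, with a plausible range from 10 nM to 200 nM.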

Compound 4, half-maximal inhibitory concentration: 20 nM
Estimate against measurement, compound 4: 2.0-fold (0.30 log units) above; measured number inside the range.
By their numbers in this assay, from the lowest: compounds 2, 4 and 1 (each within the scatter of the next); then compound 3.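

In this assay, within the data shown here, the single change at this place, on an oxygen on a saturated carbon, swaps one five-membered non-aromatic ring of carbon only for one four-membered non-aromatic ring of carbon only and gives a large step (a 73-fold lower number from compound 3 to compound 4 (1.86 log units; beyond the scatter)) beyond the scatter. Compound 3 differs from compound 1 and compound 2 in more than one place, so those compounds could not isolate the ring; this pair ties the gap to the ring itself, with the group count otherwise unchanged under the same two defined stereocentres and the same double bonds outside aromatic rings. No measurement here bears on the origin of this step, and the pair gives only its size.

Among these compounds, whether a step of this size also holds on the core of compound 1 or the core of compound 2 remains open, as the only five-membered example sits on the core shared by compound 3 and compound 4. Also open, as far as these compounds go, is how a six-membered carbon ring or an open propyl chain would read at this place, and how an amine would read in place of the isothiocyanate.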